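The compounds below may be only part of what the source reports. "The series", "measured", "known", "first", "only" and "open" are said of these compounds alone.

Working notes on the series

Three compounds share one core and differ only in the aryl group on the saturated ring carbon. In a functional assay on B16-F10 cells (Mus musculus) for antiproliferative activity, read by MTT assay, with a stated time of 48 h (on this read-out higher numbers stand for weaker inhibition and lower numbers for stronger inhibition), compound 1 `CC(=O)N1N=C(c2ccc3ccccc3c2)OC1c1ccccc1Br` gives 6.98 ug/mL, compound 2 `CC(=O)N1N=C(c2ccc3ccccc3c2)OC1c1cccc(Br)c1` gives 2.36 ug/mL, and compound 3 `CC(=O)N1N=C(c2ccc3ccccc3c2)OC1c1ccccc1F` gives 6.05 ug/mL. Compound 3 thus stands second highest of the three numbers; its nearest neighbour is compound 1, within the scatter, and its furthest is compound 2, beyond the scatter.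

Compound 4 `CC(=O)N1N=C(c2ccc3ccccc3c2)OC1c1ccc(C)cc1` is not yet measured. The change from compound 3 is 4-methylphenyl in place of 2-fluorophenyl on a saturated ring carbon.

For the measured compounds named here, two measured steps bear on this. a 3.0-fold lower number from compound 1 to compound 2 (0.47 log units; beyond the scatter) shows that moving the same halogen to the 3-position lowers the number; a 2.6-fold higher number from compound 2 to compound 3 (0.41 log units; beyond the scatter) shows the reverse when the ring returns to a 2-substituted pattern. a 1.2-fold lower number from compound 1 to compound 3 (0.06 log units; within the scatter) shows that swapping the halogen itself at the 2-position changes little. Going by the values given here, no compound with a 4-substituted ring or a methyl group is measured, so the step is uncertain; a modest lowering is expected, a 1.5-fold lower number from compound 3 to compound 4 (0.18 log units; within the scatter).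

Compound 4 is expected to give 4 ug/mL in this assay, within 1.8 ug/mL to 9 ug/mL.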

Compound 4, half-maximal inhibitory concentration: 3.85 ug/mL
For compound 4 the middle estimate is 1.0-fold (0.02 log units) above the measured one, and the stated range covers the measured number.
By their numbers in this assay, from the lowest: compounds 2, 4, 3 and 1 (each within the scatter of the next, the first and the last beyond it).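

The 4-methylphenyl group, which carries no halogen, lands within the scatter of all three halogen-bearing compounds (a 1.6-fold lower number from compound 3 to compound 4 (0.20 log units; within the scatter)) (a 1.6-fold higher number from compound 2 to compound 4 (0.21 log units; within the scatter)) (a 1.8-fold lower number from compound 1 to compound 4 (0.26 log units; within the scatter)). The saturated ring carbon therefore accepts an aryl group without a halogen while the number stays inside the range already spanned in this assay, and compound 4 cannot be ranked against any single neighbour, even though compounds 1 and 2 stand beyond the scatter of each other. No supporting evidence bears on this result.

Among the compounds shown, the methyl group and the halogens never share a ring pattern, so the effect of the substituent cannot be separated from that of its placement. Going by these compounds, how an amine or a carboxylic acid in place of the methyl group would read also remains open.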